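The source may report more compounds than this note shows. Statements on the series, on what has been measured and on what is new or still open speak of the compounds shown alone.

Two isatin-type compounds have been run in a functional assay on K562 cells (Homo sapiens) for antiproliferative activity, read by MTT assay, with a stated time of 48 h (a lower number here means a stronger inhibitor, a higher number a weaker inhibitor), so far. Compound 1 `COc1ccc(-c2ccc3c(c2)C(=O)C(=O)N3Cc2cccc(Cl)c2)cc1` gives 200 nM in this assay, and compound 2 `COc1ccc(CN2C(=O)C(=O)c3cc(-c4ccc(OC)c(OC)c4)ccc32)cc1` gives 260 nM in this assay. On these two numbers compound 2 stands highest, but its nearest neighbour, compound 1, sits only a small distance away, and that distance lies within the scatter of repeated measurements, so the two compounds cannot be told apart in this assay.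

Compound 3 `COc1ccc(CN2C(=O)C(=O)c3cc(-c4ccc(C#N)cc4)ccc32)cc1` is the next compound in line and has not yet been measured. It differs from compound 2 in one place: 4-cyanophenyl in place of 3,4-dimethoxyphenyl on an aromatic carbon. The 4-cyanophenyl carries a single hydrogen-bond acceptor in place of the two of the 3,4-dimethoxyphenyl, and the substituent sits on the same aromatic carbon of the fused core.

Going by the values given here, no step between measured compounds is available that would show what such an exchange does in this assay, so the direction is open. A step from compound 2 to compound 3 of modest size toward a higher number, a 1.5-fold higher number from compound 2 to compound 3 (0.19 log units; within the scatter), is expected, though a step within the scatter in either direction would not be surprising. For compound 3 the expected value in this assay is 400 nM, with a range from 120 nM to 1300 nM.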

Compound 3, half-maximal inhibitory concentration: 260 nM
Compound 3: middle estimate off by 1.5-fold (0.19 log units), on the high side; measured number inside the range.
By their numbers in this assay, from the lowest: compounds 1, 2 and 3 (each within the scatter of the next).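

Going by these compounds alone, this is the first step that can be read between two compounds differing in one place: in this assay, 4-cyanophenyl in place of 3,4-dimethoxyphenyl on the aromatic carbon gives no change at the digits printed from compound 2 to compound 3 (within the scatter). This position therefore accepts both aryl groups without a difference that this read-out can resolve, even though the exchange removes both methoxy groups and brings in a nitrile. Nothing available explains why the two compounds read alike, and no other measurement bears on the result.

The compounds shown leave open whether this insensitivity extends beyond substituted phenyl rings, for instance to a phenyl ring carrying an amine or a carboxylic acid at this carbon, or to a longer alkyl chain in place of the ring. Within the data shown here, they also leave open whether 4-cyanophenyl would read the same way on the core of compound 1, which carries a different group on the ring nitrogen, since only one such exchange is available here.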